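This account rests on a few compounds, and the source may have more. Where it says the series, first, only, none or still open, it means among the compounds named here.

Measured so far:
compound 1, `O=C1NC(=O)C(Cc2ccc(Oc3ccc(Cl)cc3Cl)cc2C(F)(F)F)S1`: 88 nM
compound 2, `Cc1cccc(Oc2ccc(CC3SC(=O)NC3=O)cc2)c1`: 203 nM

Both numbers come from a functional assay for agonist activity at Free fatty acid receptor 1 (Homo sapiens), read by FLIPR, in the presence of a further agent that is not named here; a higher number here means that more compound is needed for the effect, a lower number that less compound is needed. Compound 2 has the higher of the two; compound 1 sits below it by a gap beyond the usual scatter. Compound 3, `Cc1ccccc1Oc1ccc(CC2SC(=O)NC2=O)cc1`, is not yet measured. It differs from compound 2 in one place: 2-methylphenyl in place of 3-methylphenyl on an oxygen on an aromatic ring. Going by the values given here, no measured pair shows what this kind of change does here, so the step is expected to be small, in no clear direction beyond the scatter: a 1.2-fold higher number from compound 2 to compound 3 (0.09 log units; within the scatter). Compound 3 is expected to give about 250 nM, within a range from 100 nM to 700 nM.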

Compound 3, half-maximal effective concentration: 124 nM
Beside the measured number, compound 3's estimate is 2.0-fold (0.30 log units) above it; low and high end bracket the measured number.
By their numbers in this assay, from the lowest: compounds 1, 3 and 2 (each within the scatter of the next, the first and the last beyond it).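

Moving the methyl group, so that 2-methylphenyl replaces 3-methylphenyl on an oxygen on an aromatic ring, gives a 1.6-fold lower number from compound 2 to compound 3 (0.21 log units; within the scatter) in this assay. This first measured pair at this position shows that the two methylphenyl groups cannot be told apart in this measurement. No measurement shown offers an explanation for this result.

Still open, as far as these compounds go, is whether a chlorine, a methoxy group or a longer chain in place of the methyl would give a step beyond the scatter. Compound 1 differs from compound 3 in more than one place, so it cannot settle this.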